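The compounds below may be only part of what the source reports. "The series", "measured", "known", "first", "only" and "open" are said of these compounds alone.

Three compounds have been measured in a functional assay on ZR-75-1 cells (Homo sapiens) for cytotoxicity, read by sulforhodamine B assay, with a stated time of 72 h; on this read-out higher numbers stand for an effect only at larger amounts of compound and lower numbers for an effect already at smaller amounts:
compound 1 `CCCC[C@@H](/C=C\[C@@H]1OC(=O)C=C[C@@H]1O)OC(C)=O` gives 1.9 ug/mL;
compound 2 `CC(=O)O[C@H](/C=C\[C@H]1CC=CC(=O)O1)C[C@@H](OC(C)=O)[C@H](C)OC(C)=O` gives 6.4 ug/mL;
compound 3 `CCCC[C@@H](/C=C\[C@@H]1OC(=O)C=C[C@@H]1OC(C)=O)OC(C)=O` gives 3.6 ug/mL.

Compound 3 stands second highest of these three numbers. Its nearest neighbour is compound 2 and its furthest is compound 1, yet both gaps fall within the usual scatter, so no ranking of the three can be read from them. For the measured compounds named here, the only step between two measured compounds that differ in a single place is a 1.9-fold higher number from compound 1 to compound 3 (0.28 log units; within the scatter), an acetyl added on an oxygen on a saturated carbon that left the number essentially where it was.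

Compound 4 `CCCC[C@H](O)/C=C\[C@@H]1OC(=O)C=C[C@@H]1OC(C)=O` has not yet been measured. It arises from compound 3 by hydrogen in place of acetyl on an oxygen on a saturated carbon, which read one bond further out is acetoxy to hydroxy. Going by the values given here, no measured step removes an acetyl at this place, so the only guide is the step from compound 1 to compound 3, which stayed within the scatter. Exchanging acetyl for hydrogen is therefore expected to move the number little, a 1.2-fold lower number from compound 3 to compound 4 (0.08 log units; within the scatter). Compound 4 is estimated at 3 ug/mL, with a range from 1.5 ug/mL to 6.5 ug/mL.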

Compound 4, concentration for half-maximal effect: 1.6 ug/mL
The estimate for compound 4 lay 1.9-fold (0.27 log units) above the measured number, within the range that was stated.
By their numbers in this assay, from the lowest: compounds 4, 1, 3 and 2 (each within the scatter of the next, the first and the last beyond it).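

For the compounds shown here, exchanging the acetyl for hydrogen on the oxygen on a saturated carbon whose other neighbours are saturated chain carbon gives a 2.3-fold lower number from compound 3 to compound 4 (0.35 log units; beyond the scatter) in this assay and is the first single-place step here to pass beyond the scatter, though only modestly. The earlier step, a 1.9-fold higher number from compound 1 to compound 3 (0.28 log units; within the scatter) with an acetyl added on a different oxygen, stayed within the scatter, so the two oxygens need not be treated alike. Nothing at hand accounts for this shift.

The compounds shown leave open what a methyl ether or a longer acyl group such as butyryl would do on this oxygen, and whether an amine in its place would hold the number at this level. They also leave open whether the same exchange would read alike on other cell lines.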